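A few compounds are considered here, and "the series" means these few. Any claim that something is new, unique, unknown or untested is made for them only; others in the source may bear on it.

Working notes on the series in an assay on membranes from brain for displacement of a labelled ligand from Sigma non-opioid intracellular receptor 1 (Cavia porcellus), read by scintillation counting, with a stated time of 120 min; on this read-out lower numbers stand for stronger inhibition and higher numbers for weaker inhibition.

Of the compounds shown here, three have numbers so far. Compound 1 `c1ccc(CN2CCC3(CC2)OCCc2c3csc2-c2ccccc2)cc1` gives 4.5 nM. Compound 2 `COC1Cc2c(csc2-c2ccc([N+](=O)[O-])cc2)C2(CCN(Cc3ccccc3)CC2)O1`, which carries a nitro group on its pendant phenyl ring, gives 1 nM. Compound 3 `COc1ccc(-c2cc3c(s2)C2(CCN(Cc4ccccc4)CC2)OC(OC)C3)cc1` gives 56 nM, the highest of the three numbers; its nearest neighbour is compound 1, whose number is lower by a margin beyond the usual scatter, and compound 2 stands further off still. Compound 3 is therefore the weakest binder among the compounds measured.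

The next step keeps the core of compound 3 and changes only the substituent on the pendant phenyl ring: cyano in place of methoxy on an aromatic carbon, giving compound 4 `COC1Cc2cc(-c3ccc(C#N)cc3)sc2C2(CCN(Cc3ccccc3)CC2)O1`. Within the data shown here, no pair of measured compounds shows exactly this exchange, so its size is not known from the series itself. What the measured values do show is that the unsubstituted phenyl of compound 1 and the nitrophenyl of compound 2 both sit well below compound 3 in this assay, so the methoxy-bearing ring is the outlier among the three.

On that basis compound 4 is expected to move back toward the lower numbers, by a step from compound 3 to compound 4 of about a 7.0-fold lower number from compound 3 to compound 4 (0.85 log units; beyond the scatter), beyond the scatter. The estimate for compound 4 is 8 nM, with a range from 2 nM to 40 nM.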

Compound 4, inhibition constant: 20 nM
Compound 4: middle estimate off by 2.5-fold (0.40 log units), on the low side, and the stated range covers the measured number.
By their numbers in this assay, from the lowest: compound 2; then compound 1; then compound 4; then compound 3.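

In this assay, among these compounds, the exchange of 4-methoxyphenyl for 4-cyanophenyl gives a 2.8-fold lower number from compound 3 to compound 4 (0.45 log units; beyond the scatter) and is the first step that isolates a single change, here on an aromatic carbon para to a large group. The step is modest but lies beyond the scatter, so this position registers the exchange on the core shared by these two compounds. Methoxy and cyano are alike in their counts of heavy atoms and hydrogen-bond acceptors, so those counts do not separate the two groups, and no measured property bears on why the number moves.

The compounds shown leave open whether the same exchange would give a step of similar size on the core of compound 1 or compound 2, since neither forms a matched pair with it. They also leave open how this position would read with an amine, a carboxylic acid or a longer chain such as ethoxy in place of cyano, so one step does not yet give a trend at this position.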